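The compounds below may be only part of what the source reports. "The series", "measured", "known", "first", "only" and "open" are said of these compounds alone.

Compound 2 `COc1cccc(OC)c1OCCNCCOc1ccccc1OCc1cccc(Cl)c1` is one of two measured analogues sharing a core; the other is compound 1 `COc1cccc(OC)c1OCCNCCOc1ccccc1OCc1ccccc1Cl`. In a functional assay on PC-3 cells (Homo sapiens) for cytotoxicity, read by sulforhodamine B assay (on this read-out higher numbers stand for weaker inhibition of growth and lower numbers for stronger inhibition of growth), compound 1 gives 5400 nM, and in this assay compound 2 gives 5900 nM. The step of a 1.1-fold higher number from compound 1 to compound 2 (0.04 log units; within the scatter) shows that the two values lie within the scatter of each other, so compound 2 is not set apart from compound 1 on these numbers.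

Compound 3 `COc1cccc(OC)c1OCCNCCOc1ccccc1OCc1ccccc1C` is not yet measured. It differs from compound 2 by 2-methylphenyl in place of 3-chlorophenyl on a saturated chain carbon bound to an oxygen on an aromatic ring. Within the data shown here, only one measured step bears on this change: the move a 1.1-fold higher number from compound 1 to compound 2 (0.04 log units; within the scatter), which exchanged one chlorophenyl for another at the same place and left the number unchanged. Among the measured compounds shown here, with no step showing any effect of this part of the molecule, the step from compound 2 to compound 3 is expected to be a 1.1-fold lower number from compound 2 to compound 3 (0.03 log units; within the scatter), none beyond the scatter. Compound 3 is therefore estimated at 5500 nM, between 2500 nM and 12000 nM.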

Compound 3, concentration for 50% growth inhibition: 11500 nM
For compound 3 the middle estimate is 2.1-fold (0.32 log units) below the measured one; the range from low to high includes it.
By their numbers in this assay, from the lowest: compounds 1, 2 and 3 (each within the scatter of the next, the first and the last beyond it).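

In this assay, the earlier pair had shown nothing on exchanging one chlorophenyl for the other, whereas methyl in place of chloro at the same place gives the first step beyond the scatter in this set (a 2.1-fold higher number from compound 1 to compound 3 (0.33 log units; beyond the scatter)), a modest one towards weaker inhibition of growth. The step from the 3-chlorophenyl analogue (a 1.9-fold higher number from compound 2 to compound 3 (0.29 log units; within the scatter)) stays within the scatter, so compound 3 is not set apart from compound 2. Among these compounds, the position therefore responds to change, but only slightly, the one step beyond the scatter rests on a single pair, and nothing measured here speaks to its cause.

Going by these compounds, whether the plain benzyl group, a 3-methylphenyl, or an amine or a carboxylic acid on this ring would shift the number further remains open. So does whether this modest step holds in any other cell line.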